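From cyclopropyl to cyclopentyl on an aromatic nitrogen

A few compounds are considered here, and "the series" means these few. Any claim that something is new, unique, unknown or untested is made for them only; others in the source may bear on it.

In an ADME assay on C8166 cells (Homo sapiens) for cytotoxicity, read by MTT assay (a higher number here means that more compound is tolerated, a lower number that less compound is tolerated), compound 1 (`CCCCCn1cc(C(=O)O)c(=O)c2c(O)c(Cc3cccc(Cl)c3F)ccc21`) gives 39900 nM and compound 2 (`O=C(O)c1cn(C2CC2)c2ccc(Cc3cccc(Cl)c3F)c(O)c2c1=O`) gives 39100 nM as its value, so the two stand level. Compound 3 (`O=C(O)c1cn(C2CCCC2)c2ccc(Cc3cccc(Cl)c3F)c(O)c2c1=O`) has not yet been measured. It differs from compound 2 in one place, with cyclopentyl in place of cyclopropyl on an aromatic nitrogen. For the measured compounds named here, the only measured step at this nitrogen is a 1.0-fold lower number from compound 1 to compound 2 (0.01 log units; within the scatter) for cyclopropyl in place of pentyl, so no step beyond the scatter is expected in this assay for the exchange to cyclopentyl. Going by the values given here, a single step is thin evidence, and no compound with a cyclopentyl group has a value yet. The estimated step is a 1.0-fold lower number from compound 2 to compound 3 (0.00 log units; within the scatter) on this reasoning. Compound 3 is expected at 39000 nM with an estimated range from 19000 nM to 78000 nM in this assay's read-out.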

Compound 3, half-maximal cytotoxic concentration: 12400 nM
For compound 3 the middle estimate is 3.1-fold (0.50 log units) above the measured one; measured number below the stated range.
By their numbers in this assay, from the lowest: compound 3; then compounds 2 and 1 (each within the scatter of the next).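

In this assay the group on the aromatic nitrogen now proves able to shift the number beyond the scatter: there is a 3.2-fold lower number from compound 2 to compound 3 (0.50 log units; beyond the scatter) with cyclopentyl in place of cyclopropyl, and a 3.2-fold lower number from compound 1 to compound 3 (0.51 log units; beyond the scatter) with cyclopentyl in place of pentyl. The lower number therefore goes with cyclopentyl in particular, and not with a ring as such, since cyclopropyl, also a ring, stands level with the open pentyl chain. Nothing in the data shown explains this difference.

The three compounds leave open whether the number keeps falling as the ring grows, or whether cyclopentyl stands alone, which a cyclobutyl or a cyclohexyl group at this nitrogen could help to settle. They also leave open how a chain carrying an amine or a hydroxyl group would compare here.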